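Cinnamamide swap: trifluoromethoxyphenyl for fluoromethoxyphenyl

The source may hold more compounds than are shown below. What is called first, only, known or untested is meant among the compounds shown, and "the series" means these compounds.

Measured so far:
Compound 1, `COc1ccc(C(=O)c2cc(OC)c(OC)c(OC)c2)cc1NC(=O)/C=C/c1ccc(F)cc1`, 1800 nM
Compound 2, `COc1cc(/C=C/C(=O)Nc2cc(C(=O)c3cc(OC)c(OC)c(OC)c3)ccc2OC)ccc1F`, 7700 nM

Both compounds share a core and differ only in the substituted phenyl on the double-bonded chain. In a functional assay on HT-29 cells (Homo sapiens) for cytotoxicity, read by MTT assay, with a stated time of 72 h (on this read-out higher numbers stand for weaker inhibition and lower numbers for stronger inhibition), compound 2 gives 7700 nM, the higher of the two numbers shown; the only measured step, a 4.3-fold higher number from compound 1 to compound 2 (0.63 log units; beyond the scatter), comes from adding a methoxy group. Compound 3, `COc1ccc(C(=O)c2cc(OC)c(OC)c(OC)c2)cc1NC(=O)/C=C/c1cccc(OC(F)(F)F)c1`, is not yet measured. It differs from compound 2 by 3-(trifluoromethoxy)phenyl in place of 4-fluoro-3-methoxyphenyl on a double-bonded chain carbon bound to a double-bonded chain carbon. Within the data shown here, no measured step covers a trifluoromethoxy group, so the expectation rests on the one step available, which showed that the added methoxy group of compound 2 was a weakening change; its removal in compound 3 may reverse part of that. Compound 3 is therefore expected to land near compound 1, with the step estimated as a 2.6-fold lower number from compound 2 to compound 3 (0.41 log units; beyond the scatter). The estimate for compound 3 in this assay is 3000 nM, in the range 900 nM to 10000 nM.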

Compound 3, half-maximal inhibitory concentration: 5200 nM
Compound 3: the middle estimate sits 1.7-fold (0.24 log units) below what was measured; low and high end bracket the measured number.
By their numbers in this assay, from the lowest: compound 1; then compounds 3 and 2 (each within the scatter of the next).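

In this assay, the exchange of 4-fluoro-3-methoxyphenyl for 3-(trifluoromethoxy)phenyl gives a 1.5-fold lower number from compound 2 to compound 3 (0.17 log units; within the scatter), so these two groups cannot be told apart at this place on the chain. The exchange of 4-fluorophenyl for the same 3-(trifluoromethoxy)phenyl gives a 2.9-fold higher number from compound 1 to compound 3 (0.46 log units; beyond the scatter), which shows that the methoxy group of compound 2 is not the only change here that moves the number beyond the scatter, and always upward in the cases shown. Nothing available explains why these groups compare as they do. The compounds shown leave open how a plain phenyl, a chlorophenyl, or a phenyl carrying an amine or a carboxylic acid would stand at this place. They also leave open whether the fluorine of compound 1 contributes to its lower number at all.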